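A Sulfamoyl Swap on a Benzamide Bile Acid Receptor Ligand

The compounds below may be only part of what the source reports. "The series", "measured", "known", "first", "only" and "open" are said of these compounds alone.

Compound 1 `CC(C)Oc1ccc(CNC(=O)c2ccc(C(C)(C)C)cc2)cc1` was tested in an assay on HeLa cells with Bile acid receptor (Homo sapiens) as the target, read by a luciferase reporter, with a stated time of 24 h (on this read-out higher numbers stand for an effect only at larger amounts of compound and lower numbers for an effect already at smaller amounts), and gives 170 nM. Two further measured compounds sit alongside it: compound 2 `O=C(O)c1ccc(CNC(=O)c2cccc(-c3ccccc3)c2)cc1` gives 670 nM, and compound 3 `O=C(O)c1ccc(CNC(=O)c2ccc(-c3ccccc3)cc2)cc1` gives 440 nM. Compound 1 thus holds the lowest of the three numbers, and its gaps to compound 3 and to compound 2 both lie beyond the usual scatter. Compound 4 `CC(C)(C)c1ccc(C(=O)NCc2ccc(S(N)(=O)=O)cc2)cc1` has not yet been measured. It differs from compound 1 in one place: sulfamoyl in place of isopropoxy on an aromatic carbon. Going by the values given here, no measured pair shows the effect of this exchange, so the expectation rests on compound 1 with its value 170 nM, and the step of a 2.9-fold higher number from compound 1 to compound 4 (0.47 log units; beyond the scatter) is expected to run toward a higher number. Compound 4 is accordingly estimated at 500 nM, within a range from 150 nM to 2000 nM.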

Compound 4, half-maximal effective concentration: 1400 nM
Compound 4: middle estimate off by 2.8-fold (0.45 log units), on the low side, within the range that was stated.
By their numbers in this assay, from the lowest: compound 1; then compounds 3 and 2 (each within the scatter of the next); then compound 4.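

In this assay, going by these compounds alone, sulfamoyl in place of isopropoxy, para to a large group, gives an 8.2-fold higher number from compound 1 to compound 4 (0.92 log units; beyond the scatter), the first one-place comparison. The two groups have the same heavy-atom count, so that count alone does not keep the number at this position unchanged. No measurement here accounts for the step. 

Going by these compounds, it remains open whether an amine or a methoxy group at this position would give a number nearer that of compound 1 or compound 4. The shown compounds also leave open whether the same exchange would produce a similar step on another core.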